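Shortening the linker and reversing the amide in compound 3

This account rests on a few compounds, and the source may have more. Where it says the series, first, only, none or still open, it means among the compounds named here.

Three hydroxamic acids sharing one core have been measured in a functional assay on A549 cells (Homo sapiens) for inhibition; on this read-out higher numbers stand for weaker inhibition and lower numbers for stronger inhibition. Compound 1 `CC(C)c1cc(-c2n[nH]c(=O)n2-c2cccc(C(=O)NCCCCCCC(=O)NO)c2)c(O)cc1O` gives 4600 nM and compound 2 `CC(C)c1cc(-c2n[nH]c(=O)n2-c2cccc(C(=O)NCCCCCC(=O)NO)c2)c(O)cc1O` gives 4600 nM; the step of no change at the digits printed from compound 1 to compound 2 (within the scatter) shows that removing one chain carbon left the read-out unchanged. Compound 3 `CC(C)c1cc(-c2n[nH]c(=O)n2-c2cccc(NC(=O)CCCCC(=O)NO)c2)c(O)cc1O` gives 1600 nM, the lowest of the three numbers, with both other compounds beyond the scatter above it. Compound 4 `CC(C)c1cc(-c2n[nH]c(=O)n2-c2cccc(C(=O)NCCCC(=O)NO)c2)c(O)cc1O` carries (3-(hydroxycarbamoyl)propyl)carbamoyl in place of ((4-(hydroxycarbamoyl)butyl)carbonyl)amino on an aromatic carbon. Among the measured compounds shown here, only the step from compound 1 to compound 2 bears on this change, and it was flat; the reversal of the amide has no measured precedent, so its effect is unknown. A modest rise is therefore expected, a 1.9-fold higher number from compound 3 to compound 4 (0.27 log units; within the scatter), and compound 4 is estimated at 3000 nM, between 1200 nM and 8000 nM.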

Compound 4, half-maximal inhibitory concentration: 4600 nM
Estimate against measurement, compound 4: 1.5-fold (0.19 log units) below; low and high end bracket the measured number.
By their numbers in this assay, from the lowest: compound 3; then compounds 1, 2 and 4 (each within the scatter of the next).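

In this assay the swap on the aromatic carbon gives a 2.9-fold higher number from compound 3 to compound 4 (0.46 log units; beyond the scatter) and so does not retain the lower number of compound 3. Within the carbamoyl-linked compounds, shortening the chain still has no effect, with no change at the digits printed from compound 2 to compound 4 (within the scatter) and no change at the digits printed from compound 1 to compound 4 (within the scatter) showing the same flat result. No measured evidence accounts for the difference between the two linkages. From the compounds shown here alone, since the swap alters both amide direction and chain, their separate contributions remain open. Going by these compounds, how a longer or shorter chain would read on the carbonylamino linkage of compound 3 also remains open.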